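Swapping an amide for a sulfonamide on a shared core

The source may hold more compounds than are shown below. What is called first, only, known or untested is meant among the compounds shown, and "the series" means these compounds.

Of the compounds shown here, three built on one shared core have been tested. Compound 1 `O=C(/C=C/c1cccc(NC(=O)c2ccccc2Cl)c1)c1nc2ccccc2[nH]1` gives 1280 nM in a functional assay on HCT-116 cells (Homo sapiens) for antiproliferative activity, read by MTT assay, with a stated time of 48 h; on this read-out lower numbers stand for stronger inhibition and higher numbers for weaker inhibition. Compound 2 `Cc1ccccc1C(=O)Nc1cccc(/C=C/C(=O)c2nc3ccccc3[nH]2)c1` gives 1870 nM, and compound 3 `O=C(Nc1cccc(/C=C/C(=O)c2nc3ccccc3[nH]2)c1)c1cc(Cl)cc(Cl)c1` gives 1650 nM. Going by the values given here, compound 1 holds the lowest of the three numbers, yet all three lie within the scatter of one another, so no compound can be called the most potent. The step from compound 1 to compound 2 was a 1.5-fold higher number from compound 1 to compound 2 (0.16 log units; within the scatter), and the step from compound 1 to compound 3 was a 1.3-fold higher number from compound 1 to compound 3 (0.11 log units; within the scatter).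

Compound 4 `Cc1ccccc1S(=O)(=O)Nc1cccc(/C=C/C(=O)c2nc3ccccc3[nH]2)c1` has not yet been measured. It differs from compound 1 in one place:
(2-methylphenyl)sulfonyl in place of (2-chlorophenyl)carbonyl on a nitrogen on an aromatic ring
Among the compounds with values here, only the step from compound 1 to compound 2 bears on this change, and that step stayed within the scatter; no measured pair shows what a sulfonyl in place of a carbonyl does on this nitrogen. Compound 4 is therefore expected to give about 1800 nM, between 600 nM and 5500 nM. The expected step from compound 1 to compound 4 is a 1.4-fold higher number from compound 1 to compound 4 (0.15 log units; within the scatter), with a wide margin because nothing measured tests the sulfonyl itself.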

Compound 4, half-maximal inhibitory concentration: 955 nM
Compound 4: the middle estimate sits 1.9-fold (0.28 log units) above what was measured; low and high end bracket the measured number.
By their numbers in this assay, from the lowest: compounds 4, 1, 3 and 2 (each within the scatter of the next).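

Going by these compounds alone, the pair of compound 2 and compound 4 shares the 2-methylphenyl group, so it is the first direct test of a sulfonyl in place of a carbonyl on this nitrogen, and in this assay it gives a step within the scatter (a 2.0-fold lower number from compound 2 to compound 4 (0.29 log units; within the scatter)). The other two steps also change the aromatic group and stay within the scatter (a 1.3-fold lower number from compound 1 to compound 4 (0.13 log units; within the scatter); a 1.7-fold lower number from compound 3 to compound 4 (0.24 log units; within the scatter)), so across these four compounds the sulfonyl link brings no loss or gain that can be told apart from noise. Nothing on hand explains this result.

From the compounds shown here alone, with a single aryl group on the sulfonyl, it remains open whether a (2-chlorophenyl)sulfonyl or (3,5-dichlorophenyl)sulfonyl would match its carbonyl partner. The compounds shown also leave open how a methylsulfonyl or an acetyl group would behave on this nitrogen.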